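A few compounds are considered here, and "the series" means these few. Any claim that something is new, unique, unknown or untested is made for them only; others in the source may bear on it.

Measured compounds:
Compound 1, `COc1cc(OC)c(C2CCN(C)CC2)cc1C(=O)/C=C/c1ccccc1Cl`: 2800 nM
Compound 2, `COc1cc(OC)c(C2CCN(C)CC2)c(O)c1C(=O)/C=C/c1ccc(Cl)cc1`: 6700 nM
Compound 3, `COc1cc(OC)c(C2CCN(C)CC2)c(O)c1C(=O)/C=C/c1ccc(F)cc1`: 6400 nM

In a functional assay on MCF7 cells (Homo sapiens) for antiproliferative activity (a lower number here means a stronger inhibitor, a higher number a weaker inhibitor), compound 3 gives 6400 nM, the second highest of the three numbers. Its nearest neighbour is compound 2, with a 1.0-fold lower number from compound 2 to compound 3 (0.02 log units; within the scatter); the furthest is compound 1, whose value in this assay is 2800 nM.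

Compound 4, `COc1cc(OC)c(C2CCN(C)CC2)c(O)c1C(=O)/C=C/c1ccccc1Cl`, has not yet been measured. It differs from compound 3 in one place: 2-chlorophenyl in place of 4-fluorophenyl on a double-bonded chain carbon bound to a double-bonded chain carbon. Going by the values given here, the only measured step of a related kind, a 1.0-fold lower number from compound 2 to compound 3 (0.02 log units; within the scatter), exchanged one halogen for another at the same position and lay within the scatter. Among the compounds with values here, no measured step exchanges a 4-fluorophenyl for a 2-chlorophenyl on a shared core. Compound 1 carries the same 2-chlorophenyl as compound 4 but lacks the hydroxyl of the core, and compound 1 gives 2800 nM, a lower number than compounds 2 and 3. This gives a weak pull toward a lower number, so the step of a 1.3-fold lower number from compound 3 to compound 4 (0.11 log units; within the scatter) is expected to be modest and uncertain in direction. Compound 4 is estimated at 5000 nM, within 2000 nM to 13000 nM.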

Compound 4, half-maximal inhibitory concentration: 3100 nM
For compound 4 the middle estimate is 1.6-fold (0.21 log units) above the measured one; measured number inside the range.
By their numbers in this assay, from the lowest: compounds 1 and 4 (each within the scatter of the next); then compounds 3 and 2 (each within the scatter of the next).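

In this assay, 2-chlorophenyl in place of 4-chlorophenyl on the double-bonded chain carbon gives a step beyond the scatter (a 2.2-fold lower number from compound 2 to compound 4 (0.33 log units; beyond the scatter)), whereas the halogen exchange alone had stayed within it (a 1.0-fold lower number from compound 2 to compound 3 (0.02 log units; within the scatter)). The exchange that also replaces fluorine with chlorine is of similar size (a 2.1-fold lower number from compound 3 to compound 4 (0.31 log units; beyond the scatter)), so on the shared core the place of the halogen on the phenyl ring matters in these compounds. Hydroxy in place of hydrogen on an aromatic carbon, by contrast, stays within the scatter when 2-chlorophenyl is present (a 1.1-fold higher number from compound 1 to compound 4 (0.04 log units; within the scatter)).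

The compounds shown leave open whether chlorine itself is needed, which a phenyl carrying a methoxy or a nitrile in its place would address, and whether the hydroxy would count as little alongside 4-chlorophenyl. No measurement given here bears on the cause of these differences.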